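Pyridin-4-yl Replaces Dichlorophenyl on a Well-Tolerated Core

This account rests on a few compounds, and the source may have more. Where it says the series, first, only, none or still open, it means among the compounds named here.

Compound 2 `Cc1nc(-c2cccnc2)sc1-c1nnc(-c2cccc(Cl)c2Cl)o1` is tested in an ADME assay on PANC-1 cells (Homo sapiens) for cytotoxicity, read by MTT assay (a lower number here means that less compound is tolerated, a higher number that more compound is tolerated), and gives only a limit there, > 100 ug/mL. Compound 1 `Cc1nc(-c2cccnc2)sc1-c1nnc(-c2ccc(Cl)cc2)o1` likewise gives only a limit, > 100 ug/mL. Compound 3 `Cc1nc(-c2cccnc2)sc1-c1nnc(-c2ccccc2[N+](=O)[O-])o1` also reaches only a limit, > 100 ug/mL. All three values sit together at the limit of > 100 ug/mL in this assay, at which 3 of the 3 values shown sit, so compound 2 stands level with its companions. The step that the two limits leave unreadable from compound 1 to compound 2, 2,3-dichlorophenyl in place of 4-chlorophenyl on an aromatic carbon, is unreadable from two limits.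

Compound 4 `Cc1nc(-c2cccnc2)sc1-c1nnc(-c2ccncc2)o1` differs by pyridin-4-yl in place of 2,3-dichlorophenyl on an aromatic carbon. No readable measured step bears on this change. The step that the limit leaves unreadable from compound 2 to compound 4 is expected to stay within the scatter. Compound 4 is therefore estimated at 150 ug/mL, ranging from 60 ug/mL to 400 ug/mL, most probably again as a limit in this assay.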

Compound 4, half-maximal cytotoxic concentration: > 100 ug/mL
Compound 4: only a limit was reported; the forecaster's own chance of this, stated with the estimate: 80%; the middle value is on the limit's open side.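

In this assay, among these compounds, compound 4 also gives only a limit, > 100 ug/mL, so no step from compound 1 or compound 2 to compound 4 can be read. The compounds shown leave open how far any of these replacements shifts the tolerated concentration, because all of them share one limit: the limit of > 100 ug/mL in this assay, at which 4 of the 4 values shown sit.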